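The source may hold more compounds than are shown below. What is called first, only, known or untested is meant among the compounds shown, and "the series" means these compounds.

Measured compounds:
- compound 1, `COc1cccc(OC)c1OCCNCCOc1ccccc1OCc1cccc(Cl)c1`: 5900 nM
- compound 2, `COc1ccccc1COc1ccccc1OCCNCCOc1c(OC)cccc1OC`: 8900 nM

Both were tested in a functional assay on PC-3 cells (Homo sapiens) for cytotoxicity, read by sulforhodamine B assay; a higher number here means a weaker inhibitor of growth, a lower number a stronger inhibitor of growth. Of the two numbers, compound 2 carries the upper one, but only by a 1.5-fold higher number from compound 1 to compound 2 (0.18 log units; within the scatter), so the two compounds cannot be told apart on this evidence. That single step is also the only one that bears on the next change: it swapped one aromatic group for another on the same saturated chain carbon and moved the number barely at all.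

Compound 3, `CCOc1ccc(COc2ccccc2OCCNCCOc2c(OC)cccc2OC)cc1`, differs from compound 2 by 4-ethoxyphenyl in place of 2-methoxyphenyl on a saturated chain carbon bound to an oxygen on an aromatic ring. Among the measured compounds shown here, since the one comparable swap, from compound 1 to compound 2, stayed within the scatter, the expectation for this assay is a step of about no change at the digits printed from compound 2 to compound 3 (within the scatter), that is, no change beyond the scatter in either direction. Compound 3 is therefore estimated at 8900 nM, with a likely range from 3500 nM to 22000 nM.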

Compound 3, concentration for 50% growth inhibition: 5200 nM
Beside the measured number, compound 3's estimate is 1.7-fold (0.23 log units) above it; the range from low to high includes it.
By their numbers in this assay, from the lowest: compounds 3, 1 and 2 (each within the scatter of the next).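

In this assay, the place on a saturated chain carbon bound to an oxygen on an aromatic ring now holds three different aromatic groups, and no swap among them moves the number beyond the scatter: the new group gives a 1.7-fold lower number from compound 2 to compound 3 (0.23 log units; within the scatter), and set against the 3-chlorophenyl compound it gives a 1.1-fold lower number from compound 1 to compound 3 (0.05 log units; within the scatter). This extends the earlier result to 4-ethoxyphenyl, a group with 9 heavy atoms in place of the 8 of 2-methoxyphenyl, although the oxygen-bearing group differs both in its name and in its ring position, and this single step cannot separate those two differences. Nothing available speaks to why the number stays within the scatter.

All three groups shown are substituted phenyl rings, so it remains open whether a cyclohexyl ring, or a phenyl ring carrying a carboxylic acid or an amine, would give a step beyond the scatter. The compounds shown also cannot tell whether 2-ethoxyphenyl or 4-methoxyphenyl would behave the same way.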